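A few compounds are considered here, and "the series" means these few. Any claim that something is new, unique, unknown or untested is made for them only; others in the source may bear on it.

In an ADME assay on MDCK cells (Canis lupus familiaris) for cytotoxicity, read by MTT assay, with a stated time of 72 h (a higher number here means that more compound is tolerated, a lower number that less compound is tolerated), the measured compounds stand as follows

compound 1 `Cc1nc([N+](=O)[O-])cn1CC(=O)Nc1ccc(F)cc1` gives 828000 nM
compound 2 `Cc1nc([N+](=O)[O-])cn1S(=O)(=O)c1ccc(Cl)cc1` gives 578000 nM
compound 3 `Cc1nc([N+](=O)[O-])cn1S(=O)(=O)c1ccc([N+](=O)[O-])cc1` gives 611000 nM

Among these numbers compound 3 with 611000 nM holds no separate place, as it lies within the scatter of both compound 2 and compound 1. The change from compound 3 to compound 4 `CC(=O)Nc1ccc(S(=O)(=O)n2cc([N+](=O)[O-])nc2C)cc1` is acetamido in place of nitro on an aromatic carbon. Among the measured compounds shown here, one measured step bears on this carbon, a 1.1-fold higher number from compound 2 to compound 3 (0.02 log units; within the scatter), with nitro in place of chloro, and it stays within the scatter. For the measured compounds named here, compound 1 differs from compound 3 in more than one place, so it offers no direct step here. Going by the values given here, no measured compound carries acetamido on that carbon, which leaves the effect of this particular swap unshown. Among the compounds with values here, with only one step to go on, and that one within the scatter, no change beyond the scatter is expected in this assay in either direction. The estimated move is a 1.0-fold higher number from compound 3 to compound 4 (0.01 log units; within the scatter) and it is expected to remain within the scatter. For compound 4 the expected value is 620000 nM, with an estimated range from 320000 nM to 1100000 nM.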

Compound 4, half-maximal cytotoxic concentration: 1030000 nM
Estimate against measurement, compound 4: 1.7-fold (0.22 log units) below; low and high end bracket the measured number.
By their numbers in this assay, from the lowest: compounds 2, 3, 1 and 4 (each within the scatter of the next).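

In this assay, the aromatic carbon para to a large group now carries a third kind of group, and the reading is the same for each comparison: acetamido in place of nitro gives a 1.7-fold higher number from compound 3 to compound 4 (0.23 log units; within the scatter), and acetamido in place of chloro gives a 1.8-fold higher number from compound 2 to compound 4 (0.25 log units; within the scatter). The earlier compounds shown here compared only chloro and nitro here, whereas acetamido adds a carbon-containing group with 4 heavy atoms and 1 hydrogen-bond donor, and even this change stays within the scatter, so chloro, nitro and acetamido cannot be told apart at this carbon in this assay. No measurement is available that would account for these numbers.

Going by these compounds, it remains open whether any group on this carbon can move the number beyond the scatter, for example an amine, a carboxylic acid or a longer chain such as propionamido in place of acetamido. Compound 1 differs from the others in more than one place, so the effect of the sulfonyl link on its own, as against the amide-containing link of compound 1, also remains unresolved.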